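This account rests on a few compounds, and the source may have more. Where it says the series, first, only, none or still open, it means among the compounds named here.

In an ADME assay on Ava5 cells (Homo sapiens) for cytotoxicity (a lower number here means that less compound is tolerated, a higher number that more compound is tolerated), three compounds sharing one core have been measured. Compound 1 `NC(=S)Nc1cccc(OCCCCCCc2ccccc2)c1` gives 28000 nM and compound 2 `NC(=S)Nc1cccc(OCCCCCCCc2ccccc2)c1` gives 23000 nM, and the change between them is a 1.2-fold lower number from compound 1 to compound 2 (0.09 log units; within the scatter). Compound 3 `NC(=S)Nc1cccc(OCCCCCOc2ccc(F)cc2)c1` gives 5000 nM, the lowest number of the three.

Compound 4 `NC(=S)Nc1cccc(OCCCCCOc2ccc(C(=O)O)cc2)c1` alters compound 3 in one place: carboxy in place of fluoro on an aromatic carbon. This puts carboxy in place of fluoro on an aromatic carbon, para to a large group. Among the compounds with values here, no measured pair makes this exact change, so the evidence is only indirect. The closest guides are two changes at the same end of the chain, which reach compound 3 from its neighbours: a 5.6-fold lower number from compound 1 to compound 3 (0.75 log units; beyond the scatter), and a 4.6-fold lower number from compound 2 to compound 3 (0.66 log units; beyond the scatter). Within the data shown here, both are modest, so a step of similar modest size seems reasonable, although its direction is a judgement that no measured pair confirms. The expected change is a 3.2-fold higher number from compound 3 to compound 4 (0.51 log units; beyond the scatter). For compound 4 the estimated value is 16000 nM, with an expected range from 5000 nM to 50000 nM.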

Compound 4, half-maximal cytotoxic concentration: > 50000 nM
Compound 4 was reported as a limit (the forecaster's own chance of this, stated with the estimate: 15%); middle value at least 3.1-fold (0.49 log units) from the limit.
By their numbers in this assay, from the lowest: compound 3; then compounds 2 and 1 (each within the scatter of the next). At a limit, above all of these: compound 4.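

In this assay, carboxy in place of fluoro on an aromatic carbon, para to a large group, gives an at least 10-fold higher number from compound 3 to compound 4 (1.00 log units; beyond the scatter). The earlier steps shown here all changed the end of the chain as a whole, whereas this one shows that swapping a single group on the ring, with the chain left as it is, is enough to move the number beyond the scatter. Compound 4 stands at a limit and not at a number: the limit of > 50000 nM in this assay, at which 1 of the 4 values shown sits.

On these data alone, it remains open whether this step is particular to carboxy, since a methyl ester, a primary amide or a hydroxyl on the same carbon would be needed to tell. The compounds shown also cannot say how far the true value of compound 4 lies past its limit, or what the same swap would do with a longer chain.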